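A few compounds are considered here, and "the series" means these few. Any claim that something is new, unique, unknown or untested is made for them only; others in the source may bear on it.

Three compounds of the series carry numbers in a functional assay on K562 cells (Homo sapiens) for cytotoxicity, read by MTT assay, with a stated time of 72 h; on this read-out lower numbers stand for stronger inhibition of growth and higher numbers for weaker inhibition of growth. Compound 1 `CS/C(=N\C(=O)c1sccc1Cl)NC(=O)c1sccc1Cl` gives 37000 nM. Compound 2 `C[Se]/C(=N\C(=O)c1ccco1)NC(=O)c1ccco1` gives 8780 nM, the second highest number of the three. Compound 3 `C[Se]/C(=N\C(=O)c1cccs1)NC(=O)c1cccs1` gives 6070 nM; the gap between compound 2 and compound 3 lies within the scatter, whereas the gap from compound 2 to compound 1 lies beyond it, compound 1 carrying the higher number.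

Compound 4 `O=C(/N=C(/NC(=O)c1ccco1)[Se]Cc1ccccc1)c1ccco1` has not been measured in this assay. It differs from compound 2 by phenyl in place of hydrogen on a saturated chain carbon bound to a selenium atom. Among the measured compounds shown here, no measured pair shows this change, so its size cannot be read from the series; a step of about the scatter or less is expected, direction open. Compound 4 is expected to give 6000 nM in this assay, between 2000 nM and 20000 nM. That estimate implies the step of a 1.5-fold lower number from compound 2 to compound 4 (0.17 log units; within the scatter).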

Compound 4, concentration for 50% growth inhibition: 9530 nM
The estimate for compound 4 lay 1.6-fold (0.20 log units) below the measured number; the range from low to high includes it.
By their numbers in this assay, from the lowest: compounds 3, 2 and 4 (each within the scatter of the next); then compound 1.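

In this assay, among the compounds shown here, the change from methyl to benzyl gives a 1.1-fold higher number from compound 2 to compound 4 (0.04 log units; within the scatter) as the first single-place step. This position therefore accepts phenyl in place of hydrogen on a saturated chain carbon bound to a selenium atom with no shift beyond the scatter, at least on the core of compound 2. No supporting data offer an explanation for this step. Still open, going by these compounds, is whether an amine, a carboxylic acid or a longer chain at this place would shift the number, and whether phenyl behaves alike on the core of compound 3.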